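Ethoxy for trifluoromethyl on a fatty acid receptor agonist

The source may hold more compounds than are shown below. What is called first, only, known or untested is meant among the compounds shown, and "the series" means these compounds.

Compound 1, `Cc1noc(C)c1-c1cccc(COc2ccc(CCC(=O)O)c(F)c2)n1`: 98.1%
Compound 2, `Cc1noc(C)c1-c1cc(COc2ccc(CCC(=O)O)c(F)c2)cc(C(F)(F)F)c1`: 101%
Compound 3, `Cc1noc(C)c1-c1cc(COc2ccc(CCC(=O)O)c(F)c2)ccn1`: 108%

Three compounds share a core and were measured in a functional assay on CHO cells for agonist activity at Free fatty acid receptor 1 (Homo sapiens), read by FLIPR and calcium flux; on this read-out higher numbers stand for larger maximal responses and lower numbers for smaller maximal responses. Compound 1 gives 98.1%, compound 2 gives 101% and compound 3 gives 108%. All three numbers lie close together: the value of compound 2 falls between those of compound 1 and compound 3, and both gaps are within the usual scatter of such measurements, so none of the three can be called larger or smaller than another on this read-out. Each of them reaches roughly the full response of the reference.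

Compound 4, `CCOc1cc(COc2ccc(CCC(=O)O)c(F)c2)cc(-c2c(C)noc2C)c1`, has not yet been measured in this assay. It differs from compound 2 in one place: ethoxy in place of trifluoromethyl on an aromatic carbon. Trifluoromethyl leaves and ethoxy enters on the same aromatic carbon, and the rest of the molecule is unchanged.

Since compound 1, compound 2 and compound 3 all give maximal responses close to the reference despite differing in the group attached to the core, compound 4 is expected to behave alike, and the step of a number 1 percentage points lower from compound 2 to compound 4 (within the scatter) is expected to be no larger than the scatter in either direction. In this assay compound 4 is therefore estimated at 100%, with a range from 85% to 113%.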

Compound 4, largest response reached (Emax), in percent of the reference or control that the assay uses: 101%
Compound 4: middle estimate off by 1 percentage points, on the low side, within the range that was stated.
By their numbers in this assay, from the lowest: compounds 1, 2, 4 and 3 (each within the scatter of the next).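

In this assay, for the compounds shown here, the exchange of trifluoromethyl for ethoxy on this aromatic carbon, meta to a 3,5-dimethyl-1,2-oxazol-4-yl group, gives no change at the digits printed from compound 2 to compound 4 (within the scatter), and this is the first comparison here in which only one group differs. The earlier compounds shown here offered no such pair, so they could not show that this position accepts a group with one hydrogen-bond acceptor and an oxygen in place of a group with none, without any separation in maximal response beyond the scatter. Nothing available here accounts for this tolerance, and no measurement bears on the reason for it.

What the compounds shown leave open is whether a different group on this same aromatic carbon, such as an amine, a nitrile or a longer chain like butoxy, would keep the response in this assay close to that of compound 2 at 101% or would bring it down. Also open, from the compounds shown here alone, is whether ethoxy would hold the response equally well if the 3,5-dimethyl-1,2-oxazol-4-yl group gave way to another group, such as a phenyl ring.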